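The compounds below may be only part of what the source reports. "The series", "measured", "known", "first", "only" and "open" are said of these compounds alone.

Three measured compounds share one core, a sulfonamide joined through a three-carbon chain to an amine that carries a benzylic group. Compound 1 `COc1cccc(CNCCCNS(=O)(=O)c2cc(C(F)(F)F)cc(C(F)(F)F)c2)c1` gives 6400 nM in a functional assay on Capan-2 cells (Homo sapiens) for inhibition, read by MTT assay, with a stated time of 72 h; a higher number here means a weaker inhibitor of growth, a lower number a stronger inhibitor of growth. Compound 2 `O=S(=O)(NCCCNCc1ccc(-c2ccccc2)cc1)c1cc(C(F)(F)F)cc(C(F)(F)F)c1` gives 2200 nM in this assay, and compound 3 `O=S(=O)(NCCCNCc1ccc(Cl)c(C(F)(F)F)c1)c1cc(C(F)(F)F)cc(C(F)(F)F)c1` gives 9100 nM in this assay. Compound 3 has the highest number of the three; against compound 1 the gap is small, and this assay shows a step of a 1.4-fold higher number from compound 1 to compound 3 (0.15 log units; within the scatter), which stays within the scatter. Against compound 2 the gap is larger and lies beyond the scatter.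

The unmeasured compound 4 `O=S(=O)(NCCCNCc1ccccc1)c1cc(C(F)(F)F)cc(C(F)(F)F)c1` differs from compound 3 in one place: phenyl in place of 4-chloro-3-(trifluoromethyl)phenyl on a saturated chain carbon bound to an amine nitrogen. Going by the values given here, the only measured step that bears on a change on this saturated chain carbon bound to an amine nitrogen is the one from compound 1 to compound 3, and it was within the scatter. Among the compounds with values here, with a smaller group entering, and the single relevant step small, no movement beyond the scatter in this assay is expected, with a wide range allowed. Compound 4 is therefore estimated at 7000 nM, within 2500 nM to 20000 nM, which as a step means a 1.3-fold lower number from compound 3 to compound 4 (0.11 log units; within the scatter).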

Compound 4, concentration for 50% growth inhibition: 14000 nM
Compound 4: middle estimate off by 2.0-fold (0.30 log units), on the low side; the measured number falls inside the stated range.
By their numbers in this assay, from the lowest: compound 2; then compounds 1, 3 and 4 (each within the scatter of the next, the first and the last beyond it).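

In this assay, stripping the ring down to plain phenyl on the saturated chain carbon bound to an amine nitrogen gives a 1.5-fold higher number from compound 3 to compound 4 (0.19 log units; within the scatter), so losing the chlorine and the trifluoromethyl group, and going from 11 heavy atoms to 6 in this group, does not shift the number beyond the scatter. Going by these compounds alone, compound 4 also gives the first readings for single substituents on this ring, with hydrogen in place of methoxy on an aromatic carbon giving a 2.2-fold higher number from compound 1 to compound 4 (0.34 log units; beyond the scatter), and hydrogen in place of phenyl on an aromatic carbon giving a 6.4-fold higher number from compound 2 to compound 4 (0.80 log units; beyond the scatter), both modest but beyond the scatter. A substituent on this ring thus goes with a lower number for the methoxy of compound 1 and the phenyl of compound 2, while compound 3, with its two substituents, goes against that pattern.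

Nothing given here accounts for any of these steps. The compounds shown leave open how a carboxylic acid or an amine on this ring would read in this assay, and what a longer chain linking the sulfonamide to the amine would do.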